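The compounds below may be only part of what the source reports. "The series", "measured", "known", "first", "only" and "open" are said of these compounds alone.

Compound 1 `COc1cc(OC)c(C(C#CCCc2ccc(O[Si](C)(C)C(C)(C)C)cc2)CC(=O)c2ccc(O)cc2)c(OC)c1`: 7500 nM
Compound 2 `COc1cc(OC)c(C(C#CCCc2ccc(O[Si](C)(C)C(C)(C)C)cc2)CC(=O)c2ccc(OC(C)=O)cc2)c(OC)c1`: 8000 nM

In a functional assay on U-87MG ATCC cells (Homo sapiens) for cytotoxicity, with a stated time of 5 days (on this read-out higher numbers stand for weaker inhibition and lower numbers for stronger inhibition), compound 2 gives 8000 nM, level within the scatter with compound 1 at 7500 nM. Compound 3 `COc1cc(OC)c(C(C#CCCc2ccc(O[Si](C)(C)C(C)(C)C)cc2)CC(=O)c2ccc(O[Si](C)(C)C(C)(C)C)cc2)c(OC)c1` keeps the core of compound 2 and alters one place, on an oxygen on an aromatic ring: a group of 7 heavy atoms (6 carbon, 1 silicon; no ring) in place of a group of 3 heavy atoms (2 carbon, 1 oxygen; no ring), on an oxygen on an aromatic ring. The acetyl leaves, and a group of 7 heavy atoms takes its place.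

Going by the values given here, only one measured step bears on this oxygen: a 1.1-fold higher number from compound 1 to compound 2 (0.03 log units; within the scatter). Among the compounds with values here, that change, acetyl in place of hydrogen, stayed within the scatter, so the one swap tested here shows no measurable effect. Within the data shown here, no measurement yet tests a group of this size at this oxygen, so the expectation remains uncertain. The expected change is a 1.1-fold lower number from compound 2 to compound 3 (0.06 log units; within the scatter), with no step beyond the scatter anticipated. Compound 3 is estimated at 7000 nM, with an expected range from 2500 nM to 20000 nM.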

Compound 3, half-maximal inhibitory concentration: 19100 nM
Beside the measured number, compound 3's estimate is 2.7-fold (0.44 log units) below it; the range from low to high includes it.
By their numbers in this assay, from the lowest: compounds 1 and 2 (each within the scatter of the next); then compound 3.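

This oxygen on an aromatic ring does respond to what it carries. In this assay the group of 7 heavy atoms (6 carbon, 1 silicon; no ring) gives a 2.4-fold higher number from compound 2 to compound 3 (0.38 log units; beyond the scatter) when it replaces acetyl and a 2.5-fold higher number from compound 1 to compound 3 (0.41 log units; beyond the scatter) when it replaces hydrogen on the same oxygen. Hydrogen and acetyl had stayed level, so this is the first change here to move the number beyond the scatter, and it moves towards weaker inhibition, although nothing available explains the shift.

From the compounds shown here alone, whether a methyl or a longer carbon chain on this oxygen would shift the number as well remains open. The three compounds therefore cannot show whether the silicon atom matters or whether an all-carbon group of similar bulk would do the same.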